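The compounds below may be only part of what the source reports. "The series", "measured", "known", "first", "only" and "open" are said of these compounds alone.

Measured compounds in a functional assay for inhibition of sodium/hydrogen exchanger (Oryctolagus cuniculus); a higher number here means a weaker inhibitor, a lower number a stronger inhibitor:
compound 1 `Cc1c(C(=O)N=C(N)N)cc(S(C)(=O)=O)c(C)c1C`: 55 nM
compound 2 `Cc1cc(-c2ccco2)c(S(C)(=O)=O)cc1C(=O)N=C(N)N`: 16 nM
compound 3 `COc1cc(Cl)c(C(=O)N=C(N)N)cc1S(C)(=O)=O`: 40 nM

Compound 2 has the lowest number of the three. Its gap to compound 3 and its gap to compound 1 both lie beyond the scatter, so on these numbers compound 2 is the strongest inhibitor of the set. Going by the values given here, no two of the measured compounds differ in only one place, so no single-point step is available to anchor a forecast.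

Compound 4 `Cc1cc(N2CCCCC2)c(S(C)(=O)=O)cc1C(=O)N=C(N)N` is not yet measured. It differs from compound 2 in one place: piperidin-1-yl in place of furan-2-yl on an aromatic carbon. The group that leaves is five-membered and aromatic, the group that enters is six-membered and non-aromatic; each counts one hydrogen-bond acceptor and no donor. Among the compounds with values here, with no comparable step among the measured compounds, the expected change in this assay is small, leaning toward a weaker inhibitor, and may not exceed the scatter. Compound 4 is expected to give about 30 nM, within 10 nM to 90 nM. The step this estimate implies is a 1.9-fold higher number from compound 2 to compound 4 (0.27 log units; within the scatter), an expectation rather than a measurement.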

Compound 4, half-maximal inhibitory concentration: 21 nM
Beside the measured number, compound 4's estimate is 1.4-fold (0.15 log units) above it, within the range that was stated.
By their numbers in this assay, from the lowest: compounds 2, 4, 3 and 1 (each within the scatter of the next, the first and the last beyond it).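

In this assay, going by these compounds alone, the aromatic carbon ortho to a methylsulfonyl group and meta to a methyl group gives the first single-place comparison, and piperidin-1-yl in place of furan-2-yl gives a 1.3-fold higher number from compound 2 to compound 4 (0.12 log units; within the scatter) as its step. At this position, then, a five-membered aromatic ring and a six-membered non-aromatic ring cannot be told apart in this assay, so on this one pair an aromatic group at that carbon is not needed to hold the value. Nothing measured here speaks to why the two groups read alike.

Still open, on these data alone, is how far this tolerance extends: an open-chain amine such as dimethylamino, a morpholine ring, a carboxylic acid or a plain hydrogen at the same carbon could each read differently. As far as these compounds go, whether the same swap behaves alike on the cores of compound 1 or compound 3 also remains unknown.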